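A few compounds are considered here, and "the series" means these few. Any claim that something is new, unique, unknown or untested is made for them only; others in the source may bear on it.

Among the measured compounds shown here, in a functional assay on U-937 cells (Homo sapiens) for antiproliferative activity, with a stated time of 48 h (on this read-out higher numbers stand for an effect only at larger amounts of compound and lower numbers for an effect already at smaller amounts), compound 1 (`Nc1ccc(NC(=O)CCCCCCC(=O)NO)cc1`) gives 6400 nM, the higher of the two numbers so far, while compound 2 (`O=C(CCCCCCC(=O)Nc1cccc(F)c1)NO`) gives 500 nM, a gap beyond the usual scatter. Compound 3 (`CN(C)c1ccc(NC(=O)CCCCCCC(=O)NO)cc1`) awaits measurement and carries dimethylamino in place of amino on an aromatic carbon, para to a large group: dimethylamino in place of amino on an aromatic carbon. With compound 2 at 500 nM as the only lower reference, a moderate fall in the number is expected in this assay, possibly close to the scatter. The expected step is a 2.9-fold lower number from compound 1 to compound 3 (0.46 log units; beyond the scatter). For compound 3 the estimate is 2200 nM, with an expected range of 600 nM to 8000 nM.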

Compound 3, half-maximal effective concentration: 1700 nM
Compound 3: middle estimate off by 1.3-fold (0.11 log units), on the high side; the range from low to high includes it.
By their numbers in this assay, from the lowest: compound 2; then compound 3; then compound 1.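

In this assay, dimethylamino in place of amino on an aromatic carbon, para to a large group, gives a 3.8-fold lower number from compound 1 to compound 3 (0.58 log units; beyond the scatter). This position therefore accepts the larger group, which has no hydrogen-bond donor, and the number still falls. No measurement shown accounts for this step.

On these data alone, it remains open whether methylamino, with a single added carbon, would fall between compound 1 and compound 3, or whether an acetamido group or a carboxylic acid at this place would lower the number or raise it.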